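The source may hold more compounds than are shown below. What is called first, only, known or untested is meant among the compounds shown, and "the series" means these compounds.

Compound 1 `O=C(NCCO)c1cccc(Nc2ncc(F)c(Nc3ccc(F)cc3)n2)c1` was tested in a functional assay on KBVIN cells (Homo sapiens) for antiproliferative activity, read by sulforhodamine B assay, with a stated time of 3 days (a lower number here means a stronger inhibitor of growth, a higher number a weaker inhibitor of growth), where compound 1 gives 21400 nM. For the measured compounds named here, of the three compounds measured so far, this is the highest number. Compound 2 `CN(C)CC(=O)Nc1cccc(Nc2ncc(F)c(Nc3ccc(F)cc3)n2)c1` gives 1810 nM, so that there is a 12-fold lower number from compound 1 to compound 2 (1.07 log units; beyond the scatter). Compound 3 `O=C(Nc1cccc(Nc2ncc(F)c(Nc3ccc(F)cc3)n2)c1)c1cnccn1` gives 20100 nM, and here there is only a 1.1-fold lower number from compound 1 to compound 3 (0.03 log units; within the scatter). Between these two, there is an 11-fold higher number from compound 2 to compound 3 (1.05 log units; beyond the scatter).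

Compound 4 `COc1cc(NC(=O)c2cccc(Nc3ncc(F)c(Nc4ccc(F)cc4)n3)c2)cc(OC)c1` has not yet been measured. It differs from compound 1 in one place: 3,5-dimethoxyphenyl in place of 2-hydroxyethyl on an amide-type nitrogen. Going by the values given here, none of the measured steps makes this exact change. The closest comparison is the step to compound 3, where ((pyrazin-2-yl)carbonyl)amino replaced (2-hydroxyethyl)carbamoyl and the number barely moved, while the large drop seen in a 12-fold lower number from compound 1 to compound 2 (1.07 log units; beyond the scatter) came with a (dimethylamino)methyl group that compound 4 does not carry. A small step is therefore expected, if any beyond the scatter, and in the direction of a lower number. Compound 4 is expected to give about 11000 nM, within a range from 3500 nM to 35000 nM. The expected step is a 1.9-fold lower number from compound 1 to compound 4 (0.29 log units; within the scatter).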

Compound 4, concentration for 50% growth inhibition: 12700 nM
Compound 4: middle estimate off by 1.2-fold (0.06 log units), on the low side; the range from low to high includes it.
By their numbers in this assay, from the lowest: compound 2; then compounds 4, 3 and 1 (each within the scatter of the next).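

Placing 3,5-dimethoxyphenyl on the amide-type nitrogen in this assay gives a 1.7-fold lower number from compound 1 to compound 4 (0.23 log units; within the scatter). A much larger group containing a six-membered aromatic ring is therefore tolerated here without a change beyond the scatter, although the number remains high. The hydrogen-bond donor of 2-hydroxyethyl is also absent from the entering group, and this pair shows no clear change in growth inhibition with that swap; no measurement here explains the result.

On these data alone, it remains open whether an amine on this nitrogen, such as a 2-(dimethylamino)ethyl chain, would lower the number beyond the scatter. Also open, as far as these compounds go, is whether a plain phenyl group without its two methoxy groups, or a carboxylic acid on the aromatic ring of the entering group, would keep the number at this level.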